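Methoxy on the fused ring of the oxindole-type series

A few compounds are considered here, and "the series" means these few. Any claim that something is new, unique, unknown or untested is made for them only; others in the source may bear on it.

Among the compounds with values here, compound 1 `COc1ccc(C2(c3cc(C(C)(C)C)ccc3O)C(=O)Nc3ccccc32)cc1` gives 15700 nM in a functional assay on cells (Mus musculus) for antiproliferative activity, read by sulforhodamine B assay, with a stated time of 5 days (a lower number here means a stronger inhibitor, a higher number a weaker inhibitor), the only number in the set. Compound 2 `CC(C)(C)c1ccc(O)c(C2(c3cccnc3)C(=O)Nc3ccccc32)c1` reaches only the limit > 20000 nM in this assay, the one limit in the set (the limit of > 20000 nM in this assay, at which 1 of the 2 values shown sits). The step of an at least 1.2-fold higher number from compound 1 to compound 2 (0.10 log units; that floor lies within the scatter) concerns the group on the saturated ring carbon, not the fused ring. Compound 3 `COc1ccc(C2(c3cc(C(C)(C)C)ccc3O)C(=O)Nc3ccc(OC)cc32)cc1` differs from compound 1 by methoxy in place of hydrogen on an aromatic carbon. Within the data shown here, no measured step touches that position, so nothing bears on it directly; a change within the scatter is expected, a 1.0-fold lower number from compound 1 to compound 3 (0.02 log units; within the scatter). Compound 3 is estimated at 15000 nM, between 6000 nM and 40000 nM.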

Compound 3, half-maximal inhibitory concentration: 14300 nM
For compound 3 the middle estimate is 1.0-fold (0.02 log units) above the measured one; measured number inside the range.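

In this assay, methoxy in place of hydrogen on this aromatic carbon gives a 1.1-fold lower number from compound 1 to compound 3 (0.04 log units; within the scatter) and so leaves the number unchanged within the scatter. Within the data shown here, this is the first reading at this position of the fused ring, and it shows that the position accepts methoxy with no readable loss or gain. No evidence at hand bears on this step.

Still open, going by these compounds, is whether an amine, a carboxylic acid or a longer alkoxy chain at this position would shift the number beyond the scatter. A fluorine or chlorine here remains equally untested by these compounds.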